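The source may report more compounds than this note shows. Statements on the series, on what has been measured and on what is new or still open speak of the compounds shown alone.

Compound 1 `Cc1cccc(C(=O)N2CCCC(C(=O)Nc3ccc(Cl)cc3)C2)c1` was examined in an ADME assay on PC-3 cells (Homo sapiens) for cytotoxicity, read by WST assay, tested at 100 uM (on this read-out higher numbers stand for more inhibition at the one concentration tested (going by the name of the read-out) and lower numbers for less inhibition), and gave 0%. Its companion, compound 2 `O=C(Nc1cccc([N+](=O)[O-])c1)C1CCCN(C(=O)c2cc(C(F)(F)F)cc(C(F)(F)F)c2)C1`, gave 9% in the same this assay. Compound 1 therefore stands at the lower of the two numbers, and the distance to compound 2 lies within the usual scatter of such measurements, so the two cannot be told apart on this read-out.

The new compound, compound 3 `O=C(Nc1ccc(Cl)cc1)C1CCCN(C(=O)c2cccc(-c3cccs3)c2)C1`, differs from compound 1 in one place: thiophen-2-yl in place of methyl on an aromatic carbon.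

For the measured compounds named here, no step between two measured compounds describes this change, so its effect is unknown. Since compound 1 shows 0% and compound 2 shows 9%, and both sit close to no inhibition, the step of a number 5 percentage points higher from compound 1 to compound 3 (within the scatter) is expected to stay within the scatter. Compound 3 is accordingly estimated to give 5% in this assay, with a range from -10% to 25%.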

Compound 3, a percentage reported as inhibition, at one concentration (the size of the read-out at that concentration, not a potency): 4%
The estimate for compound 3 lay 1 percentage points above the measured number, and the stated range covers the measured number.
By their numbers in this assay, from the lowest: compounds 1, 3 and 2 (each within the scatter of the next).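

The change from methyl to thiophen-2-yl, on an aromatic carbon meta to a large group, brings five heavy atoms and a five-membered aromatic ring to a place that previously held a single carbon. In this assay, it gives a number 4 percentage points higher from compound 1 to compound 3 (within the scatter), so this larger group at this position cannot be told apart from methyl on this read-out. No measurement at hand offers an explanation for this result.

From the compounds shown here alone, it remains open whether an amine or a carboxylic acid at the same position would give a number beyond the scatter from compound 1 in this assay. The compounds shown also leave open whether any group here would move the read-out away from the region close to no inhibition, as the single tested concentration gives no potency.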